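The source may hold more compounds than are shown below. What is called first, only, known or untested is meant among the compounds shown, and "the series" means these compounds.

Measured compounds:
Compound 1, `CCOC(=O)c1c(-c2c(Cl)c3ccccc3oc2=O)nn(-c2cccc(C)c2)c1C(=O)OCC`, gives 30000 nM in a functional assay on HeLa cells (Homo sapiens) for cytotoxicity, read by MTT assay, with a stated time of 48 h; on this read-out lower numbers stand for stronger inhibition and higher numbers for weaker inhibition.
Compound 2, `CCOC(=O)c1c(-c2cc3ccccc3oc2=O)nn(-c2cccc(C)c2)c1C(=O)OCC`, gives 245000 nM.
Compound 3, `CCOC(=O)c1c(-c2cc3ccccc3oc2=O)nn(-c2cccc(Cl)c2)c1C(=O)OCC`, gives 22000 nM.

Among these three, compound 2 stands with the highest number, that is, the weakest inhibition: compound 1 is nearer to it (an 8.2-fold higher number from compound 1 to compound 2 (0.91 log units; beyond the scatter)), while compound 3 lies furthest (an 11-fold lower number from compound 2 to compound 3 (1.05 log units; beyond the scatter)).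

Compound 4, `CCOC(=O)c1c(-c2cc3cc(OC)ccc3oc2=O)nn(-c2cccc(C)c2)c1C(=O)OCC`, has not yet been measured. It differs from compound 2 in one place: methoxy in place of hydrogen on an aromatic carbon.

Neither measured step involves a methoxy group, and neither sits at the same place as this change. The step from compound 1 to compound 2 removed a chloro from an aromatic carbon of the fused two-ring system and was modest in size; the step from compound 2 to compound 3 exchanged methyl for chloro on the separate benzene ring and was large. Both show that changes of a single group on the shared core can move this assay beyond the scatter, but in which direction a methoxy on the fused ring system will act cannot be read from them.

The expected step from compound 2 to compound 4 is therefore small, a 1.6-fold lower number from compound 2 to compound 4 (0.21 log units; within the scatter), and compound 4 is estimated at 150000 nM, within a range from 40000 nM to 500000 nM.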

Compound 4, half-maximal inhibitory concentration: 155000 nM
Compound 4: the middle estimate sits 1.0-fold (0.01 log units) below what was measured; low and high end bracket the measured number.
By their numbers in this assay, from the lowest: compounds 3 and 1 (each within the scatter of the next); then compounds 4 and 2 (each within the scatter of the next).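

Within the data shown here, compound 4 is the first in this set to carry a substituent at this position, an aromatic carbon of the fused system of two rings, meta to a fused ring and para to a fused ring. In this assay, methoxy in place of hydrogen here gives a 1.6-fold lower number from compound 2 to compound 4 (0.20 log units; within the scatter), so the read-out does not separate the two compounds, and this place on the shared core accepts a methoxy group with no readable change in the number. This differs from the two earlier single-group changes, an 8.2-fold higher number from compound 1 to compound 2 (0.91 log units; beyond the scatter) and an 11-fold lower number from compound 2 to compound 3 (1.05 log units; beyond the scatter), which were both beyond the scatter and show that not every single-group change on this core moves the number that far, although no information here explains the difference.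

From the compounds shown here alone, it remains open whether a different group at this same carbon, such as an amine, a carboxylic acid or a longer chain, would also leave the number within the scatter. Going by these compounds, it is also open whether methoxy would have the same small step on the core of compound 3, which carries chloro in place of methyl.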